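From Oxygen to Methyl on an Aromatic Nitrogen

The source may report more compounds than this note shows. Statements on the series, on what has been measured and on what is new or still open speak of the compounds shown alone.

Compound 1 `O=C1c2c[n+]([O-])c3ccccc3c2C(=O)c2[nH]c3ccccc3c21`: 200 nM
Compound 2 `O=C1c2[nH]c3ccccc3c2C(=O)c2cnc3ccccc3c21`: 1050 nM

In a functional assay on CCRF-CEM cells (Homo sapiens) for cytotoxicity, read by MTT assay, with a stated time of 3 days (on this read-out lower numbers stand for stronger inhibition and higher numbers for weaker inhibition), compound 1 gives 200 nM, the lowest of the two numbers shown. Compound 2 gives 1050 nM, a higher number that lies beyond the usual scatter. Compound 3 `C[n+]1cc2c(c3ccccc31)C(=O)c1[nH]c3ccccc3c1C2=O` differs from compound 1 in a single place: one carbon atom in place of one oxygen atom, on an aromatic nitrogen. Among the measured compounds shown here, no measured pair carries this same change, so the size of the step is uncertain. For compound 3 a modest rise in the number is expected, about a 2.0-fold higher number from compound 1 to compound 3 (0.30 log units; within the scatter). Compound 3 is therefore estimated at 400 nM, with a range from 100 nM to 1500 nM.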

Compound 3, half-maximal inhibitory concentration: 5130 nM
Beside the measured number, compound 3's estimate is 13-fold (1.11 log units) below it, and the stated range ends below it.
By their numbers in this assay, from the lowest: compound 1; then compound 2; then compound 3.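

In this assay the aromatic nitrogen proves to be a sensitive position, since replacing the oxygen with methyl brings a 26-fold higher number from compound 1 to compound 3 (1.41 log units; beyond the scatter) and so a large change from one heavy atom. Among the compounds shown here, this is the first step measured at this nitrogen, and it shows that the oxygen cannot be exchanged for methyl without a clear loss in this cell read-out. Nothing shown here accounts for the size of this step.

From the compounds shown here alone, it remains open whether the rise is specific to methyl. An ethyl group, a longer chain or a chain ending in an amine on this nitrogen could show how the number follows the group.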